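From ethoxy to dimethylcarbamoyl in compound 1

The compounds below may be only part of what the source reports. "The series", "measured", "known", "first", "only" and "open" are said of these compounds alone.

In a functional assay on SiHa cells (Homo sapiens) for antiproliferative activity, read by CCK-8 assay, with a stated time of 72 h (on this read-out higher numbers stand for weaker inhibition and lower numbers for stronger inhibition), compound 1 `CCOc1ccc(-c2cncnc2-c2cc(OC)c(OC)c(OC)c2)cc1` gives 640 nM and stands level with compound 2 `CCOc1ccc(-c2cncnc2-c2cc(OC)c(OC)c(OC)c2)cc1F` at 800 nM on these numbers. Compound 3 `CCOc1ccc(-c2cncnc2-c2cc(OC)c(OC)c(OC)c2)cc1Cl` gives 150 nM and lies lower than both.

The next structure is compound 4 `COc1cc(-c2ncncc2-c2ccc(C(=O)N(C)C)cc2)cc(OC)c1OC` which has dimethylcarbamoyl in place of ethoxy on an aromatic carbon, para to a large group dimethylcarbamoyl in place of ethoxy on an aromatic carbon and otherwise keeps the core of compound 1.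

The measured steps are halogen changes on the ring that carries the ethoxy. Fluoro in place of hydrogen gives a 1.3-fold higher number from compound 1 to compound 2 (0.10 log units; within the scatter) and chloro in place of hydrogen gives a 4.3-fold lower number from compound 1 to compound 3 (0.63 log units; beyond the scatter) while chloro in place of fluoro gives a 5.3-fold lower number from compound 2 to compound 3 (0.73 log units; beyond the scatter) as the largest step so far. Within the data shown here, none of them touches the ethoxy itself, so they offer a scale and no direct precedent. The data show no direction for this exchange. Replacing a whole group is a larger change than any of these halogen changes, so a step beyond the scatter is expected, tentatively towards a higher number and weaker inhibition. In this assay the expected step is a 4.7-fold higher number from compound 1 to compound 4 (0.67 log units; beyond the scatter) on this estimate. For compound 4 the estimated value is 3000 nM with an expected range from 700 nM to 15000 nM as a working figure.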

Compound 4, half-maximal inhibitory concentration: 20200 nM
Compound 4: middle estimate off by 6.7-fold (0.83 log units), on the low side; the whole stated range lies below it.
By their numbers in this assay, from the lowest: compound 3; then compounds 1 and 2 (each within the scatter of the next); then compound 4.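

In this assay, among these compounds, this is the first direct reading of a change at the ethoxy position itself, on an aromatic carbon para to a large group: dimethylcarbamoyl in place of ethoxy gives a 32-fold higher number from compound 1 to compound 4 (1.50 log units; beyond the scatter), well beyond the largest halogen step, a 5.3-fold lower number from compound 2 to compound 3 (0.73 log units; beyond the scatter). Among the compounds shown here, the two groups match in hydrogen-bond donors, hydrogen-bond acceptors and net charge, so those counts do not separate them; dimethylcarbamoyl differs in having more heavy atoms, a nitrogen and a double bond outside aromatic rings, and the single step cannot show which of these differences matters. No measurement available here bears on the reason for this step.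

A primary amide, a carboxylic acid or a methyl ester in this place would help show whether the step follows the carbonyl, the dimethylamino part or the overall size of the group. Going by these compounds, it also remains open whether a longer alkoxy chain such as propoxy would be tolerated, and whether chloro would still give a lower number, as in a 4.3-fold lower number from compound 1 to compound 3 (0.63 log units; beyond the scatter), with dimethylcarbamoyl in place of ethoxy.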